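Triazolothiadiazine series: aryl swap at the imine carbon

A few compounds are considered here, and "the series" means these few. Any claim that something is new, unique, unknown or untested is made for them only; others in the source may bear on it.

Measured so far in a functional assay on MCF7 cells (Homo sapiens) for inhibition, read by sulforhodamine B assay, with a stated time of 72 h; on this read-out higher numbers stand for weaker inhibition and lower numbers for stronger inhibition:
- compound 1 `COc1ccc2cc(C(C)c3nnc4n3N=C(c3ccc(Cl)cc3Cl)CS4)ccc2c1`: 14600 nM
- compound 2 `CC(c1ccc(-c2ccccc2)c(F)c1)c1nnc2n1N=C(c1ccc([N+](=O)[O-])cc1)CS2`: 7800 nM
- compound 3 `COc1ccc(C2=Nn3c(nnc3C(C)c3ccc(CC(C)C)cc3)SC2)cc1`: 5200 nM

Compound 1 gives the highest of the three numbers; the gap to compound 2 lies within the scatter, the gap to compound 3 lies beyond it. Compound 4 `COc1ccc2cc(C(C)c3nnc4n3N=C(c3ccc(OC(F)(F)F)cc3)CS4)ccc2c1` keeps the shared core of compound 1 and differs in one place: 4-(trifluoromethoxy)phenyl in place of 2,4-dichlorophenyl on a carbon with a double bond to nitrogen. Among the compounds with values here, no pair of measured compounds shows this exact change, so nothing is known about its size from the data. The step from compound 1 in this assay is expected to be small, toward a lower number at most, and may well stay within the scatter, as a 1.5-fold lower number from compound 1 to compound 4 (0.16 log units; within the scatter). Compound 4 is therefore estimated at 10000 nM, with a range of 3000 nM to 35000 nM.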

Compound 4, half-maximal inhibitory concentration: 8800 nM
For compound 4 the middle estimate is 1.1-fold (0.06 log units) above the measured one, and the stated range covers the measured number.
By their numbers in this assay, from the lowest: compounds 3, 2, 4 and 1 (each within the scatter of the next, the first and the last beyond it).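

In this assay, the aryl group on the carbon with a double bond to nitrogen now has its first single-change step: 4-(trifluoromethoxy)phenyl in place of 2,4-dichlorophenyl gives a 1.7-fold lower number from compound 1 to compound 4 (0.22 log units; within the scatter). On this core, the two aryl groups cannot be told apart, even though the entering group adds heavy atoms and a hydrogen-bond acceptor. No supporting data bear on this result. Open, on these data alone, is whether an amine or a carboxylic acid on the aryl ring at this position would move the number beyond the scatter. Also open, as far as these compounds go, is whether the same swap behaves alike with the side chains of compound 2 and compound 3.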